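Aryl substituent changes on the thiosemicarbazide series

The source may report more compounds than this note shows. Statements on the series, on what has been measured and on what is new or still open speak of the compounds shown alone.

Measured so far:
- compound 1 `C/C(NNC(=S)N1CCc2cc(C(=O)O)ccc21)=C1/C(=O)N(c2ccc3c(c2)CCC3)c2ccccc21` gives 14.3% in an assay on BaF3 cells for inhibition of thrombopoietin receptor (Homo sapiens), tested at 150 nM; a lower number here means a weaker effect, a higher number a stronger effect of the compound at the concentration tested
- compound 2 `C/C(NNC(=S)N1CCc2cc(C(=O)O)ccc21)=C1/C(=O)N(c2ccc(C)c(C)c2)c2ccccc21` gives 72.4% in this assay
- compound 3 `C/C(NNC(=S)N1CCCc2cc(C(=O)O)ccc21)=C1/C(=O)N(c2ccc(C)c(C)c2)c2ccccc21` gives 30.9% in this assay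

Compound 2 stands highest of the three in this assay, with compound 3 next and compound 1 furthest below, both gaps beyond the scatter. Compound 4 `C/C(NNC(=S)N1CCc2cc(C(=O)O)ccc21)=C1/C(=O)N(c2ccc(C)cc2)c2ccccc21` differs from compound 2 by hydrogen in place of methyl on an aromatic carbon. Within the data shown here, no measured step removes a methyl from this ring. Among the measured compounds shown here, the only step that bears on the change is a number 58.1 percentage points higher from compound 1 to compound 2 (beyond the scatter), which altered the same aryl group and was large, showing that this position is sensitive. Compound 4 is therefore expected to fall below compound 2 by a step beyond the scatter, a number 22.4 percentage points lower from compound 2 to compound 4 (beyond the scatter), though with wide uncertainty. The estimate for compound 4 in this assay is 50%, within a range of 25% to 75%.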

Compound 4, a percentage reported as inhibition, at one concentration (the size of the read-out at that concentration, not a potency): 47.8%
Compound 4: middle estimate off by 2.2 percentage points, on the high side, within the range that was stated.
By their numbers in this assay, from the lowest: compound 1; then compound 3; then compound 4; then compound 2.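

The methyl ortho to a methyl group counts on its own in this assay, with a number 24.6 percentage points lower from compound 2 to compound 4 (beyond the scatter) on its removal, so the 3,4-dimethylphenyl to 4-methylphenyl change is not neutral. The single methyl still keeps the read-out clear of the fused-ring aryl group, with a number 33.5 percentage points higher from compound 1 to compound 4 (beyond the scatter) on going to 4-methylphenyl. No measured evidence accounts for either step.

Going by these compounds, how a methoxy group or a chlorine in place of this methyl would read stays open. So does whether the same change holds on the core of compound 3.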